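Trifluoromethyl in place of methoxy on the amide-type nitrogen aryl

The compounds below may be only part of what the source reports. "The series", "measured", "known", "first", "only" and "open" are said of these compounds alone.

All three measured compounds were tested in a functional assay on MKN-74 cells (Homo sapiens) for antiproliferative activity, with a stated time of 24 h; on this read-out lower numbers stand for stronger inhibition and higher numbers for weaker inhibition:
compound 1, `NC(=O)c1c(NC(=O)c2ccccc2Cl)sc2c1CCN(C(=S)Nc1cccc3ccccc13)C2`, gives 20700 nM
compound 2, `NC(=O)c1c(NC(=O)c2ccccc2Cl)sc2c1CCN(C(=S)Nc1ccccc1C(F)(F)F)C2`, gives 1870 nM
compound 3, `COc1ccccc1NC(=S)N1CCc2c(sc(NC(=O)c3ccccc3Cl)c2C(N)=O)C1`, gives 35200 nM

Compound 3 shows the highest number of the three. Its distance to compound 1, a 1.7-fold higher number from compound 1 to compound 3 (0.23 log units; within the scatter), is within the usual scatter, so these two cannot be ranked against each other; its distance to compound 2, a 19-fold higher number from compound 2 to compound 3 (1.27 log units; beyond the scatter), is large and beyond the scatter.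

Compound 4, `NC(=O)c1c(NC(=O)c2ccccc2Cl)sc2c1CCN(C(=S)Nc1ccc(C(F)(F)F)cc1)C2`, differs from compound 3 in one place: 4-(trifluoromethyl)phenyl in place of 2-methoxyphenyl on an amide-type nitrogen. Among the measured compounds shown here, two measured steps bear on this. The step of a 19-fold higher number from compound 2 to compound 3 (1.27 log units; beyond the scatter) shows that exchanging trifluoromethyl for methoxy on the ring raised the number strongly; read backwards, returning to trifluoromethyl should lower it. The step of an 11-fold lower number from compound 1 to compound 2 (1.04 log units; beyond the scatter) also ends at a trifluoromethyl-bearing ring with a much lower number. For the measured compounds named here, in compound 4, however, the trifluoromethyl sits on a different ring carbon than in compound 2, and no measured pair isolates that change, so the expectation carries a wide range. A lower number than compound 3 is expected, about a 7.0-fold lower number from compound 3 to compound 4 (0.85 log units; beyond the scatter). For compound 4 the estimate in this assay is 5000 nM, expected between 1200 nM and 20000 nM.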

Compound 4, half-maximal inhibitory concentration: 7090 nM
The estimate for compound 4 lay 1.4-fold (0.15 log units) below the measured number; low and high end bracket the measured number.
By their numbers in this assay, from the lowest: compound 2; then compound 4; then compounds 1 and 3 (each within the scatter of the next).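

Keeping trifluoromethyl on the ring but using 4-(trifluoromethyl)phenyl in place of 2-(trifluoromethyl)phenyl gives a 3.8-fold higher number from compound 2 to compound 4 (0.58 log units; beyond the scatter), so the presence of this group does not alone set the number at this amide-type nitrogen; where it sits on the ring also counts. Even so, 4-(trifluoromethyl)phenyl still gives lower numbers than the other two aryl groups, with a 5.0-fold lower number from compound 3 to compound 4 (0.70 log units; beyond the scatter) and a 2.9-fold lower number from compound 1 to compound 4 (0.47 log units; beyond the scatter), which places both trifluoromethyl-bearing compounds below compound 1 and compound 3. No measurement shown here offers a reason for these differences.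

On these data alone, it remains open whether methoxy would respond in the same way if moved to another ring carbon. It is also unknown how this position would respond to an amine or a carboxylic acid on the aryl ring, or to a longer chain in place of that ring.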